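Aryl variation on the biphenyl tail of the legumain nitrile series

The source may hold more compounds than are shown below. What is called first, only, known or untested is meant among the compounds shown, and "the series" means these compounds.

Two compounds of the series are measured. Compound 1 `C[C@@H](C(=O)N[C@H](C#N)CC(N)=O)N(Cc1ccc(-c2cc(F)cc(F)c2)cc1)S(C)(=O)=O` carries a 3,5-difluorophenyl group and in an assay on isolated protein for inhibition of legumain (Homo sapiens), with stated times of 2 min and 60 min (a lower number here means a stronger inhibitor, a higher number a weaker inhibitor), compound 1 gives 1360 nM. Compound 2 `C[C@@H](C(=O)N[C@H](C#N)CC(N)=O)N(Cc1ccc(-c2cccc(C(F)(F)F)c2)cc1)S(C)(=O)=O` carries a 3-(trifluoromethyl)phenyl group in the same place, and in this assay compound 2 gives 601 nM. Going by the values given here, the only step between them, a 2.3-fold lower number from compound 1 to compound 2 (0.35 log units; beyond the scatter), runs from the difluoro compound to the trifluoromethyl compound. Among the compounds with values here, compound 2 therefore stands at the lower of the two numbers, with compound 1 as its only neighbour.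

Compound 3 `C[C@@H](C(=O)N[C@H](C#N)CC(N)=O)N(Cc1ccc(-c2ccc(F)cc2)cc1)S(C)(=O)=O` is not yet measured. It differs from compound 2 in one place: 4-fluorophenyl in place of 3-(trifluoromethyl)phenyl on an aromatic carbon, on an aromatic carbon, para to a large group. Within the data shown here, the single measured step bears on it only loosely, since it exchanges one fluorinated aryl group for another and the 4-fluorophenyl group of compound 3 has no direct counterpart. Among the measured compounds shown here, with no closer precedent, compound 3 is expected to fall between the two measured values, so a modest step back toward the number of compound 1 is estimated, a 1.7-fold higher number from compound 2 to compound 3 (0.22 log units; within the scatter). For compound 3 the expected value in this assay is 1000 nM, with a range from 400 nM to 2500 nM.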

Compound 3, half-maximal inhibitory concentration: 1040 nM
Estimate against measurement, compound 3: 1.0-fold (0.02 log units) below; low and high end bracket the measured number.
By their numbers in this assay, from the lowest: compounds 2, 3 and 1 (each within the scatter of the next, the first and the last beyond it).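

In this assay, the 4-fluorophenyl group of compound 3 cannot be separated from either earlier aryl group at this position: a 1.7-fold higher number from compound 2 to compound 3 (0.24 log units; within the scatter), and a 1.3-fold lower number from compound 1 to compound 3 (0.12 log units; within the scatter). The change to a single fluorine therefore gives an intermediate reading only in the loosest sense, as both of these steps lie within the scatter, while the 3-(trifluoromethyl)phenyl and 3,5-difluorophenyl groups remain apart by a 2.3-fold lower number from compound 1 to compound 2 (0.35 log units; beyond the scatter). Nothing available explains how these aryl groups relate to the numbers in this series.

On these data alone, all three compounds carry fluorine on the aryl group at this position, so it remains open how an unsubstituted phenyl group, or a phenyl group bearing a methoxy group, an amine or a carboxylic acid, would read in this assay. The position of the substituent also remains open, since the 4-fluorophenyl group of compound 3 is not matched by a 3-fluorophenyl or a 4-(trifluoromethyl)phenyl group among the compounds shown.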